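A few compounds are considered here, and "the series" means these few. Any claim that something is new, unique, unknown or untested is made for them only; others in the source may bear on it.

Measured so far in a functional assay on MDA-MB-231 cells (Homo sapiens) for antiproliferative activity, read by MTT assay, with a stated time of 72 h; a higher number here means a weaker inhibitor, a lower number a stronger inhibitor:
compound 1 `CC(=O)O[C@H]1CC[C@]2(C)[C@H](CC[C@@](C)(O)[C@H]2CC[C@@H]2C(C)=CC[C@H]3[C@H](CC[C@]3(C)O)C2(C)C)OC1(C)C`: 38000 nM
compound 2 `CC1=CC[C@H]2[C@H](CC[C@]2(C)O)C(C)(C)[C@@H]1CC[C@H]1[C@]2(C)CC[C@H](OC(=O)NCc3ccccc3)C(C)(C)O[C@H]2CC[C@@]1(C)O`: 40300 nM
compound 3 `CC1=CC[C@H]2[C@H](CC[C@]2(C)O)C(C)(C)[C@@H]1CC[C@H]1[C@]2(C)CC[C@H](OC(=O)c3ccc(F)cc3)C(C)(C)O[C@H]2CC[C@@]1(C)O`: 11300 nM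

Compound 3 has the lowest number of the three, and its steps to both others lie beyond the scatter. The next change leads to compound 4 `CC1=CC[C@H]2[C@H](CC[C@]2(C)O)C(C)(C)[C@@H]1CC[C@H]1[C@]2(C)CC[C@H](OC(=O)c3ccc(Cl)c(Cl)c3)C(C)(C)O[C@H]2CC[C@@]1(C)O`, with 3,4-dichlorophenyl in place of 4-fluorophenyl on a carbonyl carbon. Both groups hold one six-membered aromatic ring of carbon only.

Among the measured compounds shown here, three measured steps bear on this change, all at the same carbonyl carbon. Replacing methyl with 4-fluorophenyl gave a 3.4-fold lower number from compound 1 to compound 3 (0.53 log units; beyond the scatter), and replacing benzylamino with 4-fluorophenyl gave a 3.6-fold lower number from compound 2 to compound 3 (0.55 log units; beyond the scatter). Both are modest. Replacing methyl with benzylamino gave a 1.1-fold higher number from compound 1 to compound 2 (0.03 log units; within the scatter), so not every change at this carbon moved the number. For the measured compounds named here, no measured step exchanges one substituted phenyl group for another, so the direction is poorly supported. A small step is expected, since the largest step seen here is the modest 3.6-fold lower number from compound 2 to compound 3 (0.55 log units; beyond the scatter) and compound 4 keeps an aromatic ring at this carbon. The estimated step is a 1.2-fold lower number from compound 3 to compound 4 (0.08 log units; within the scatter), slightly downward and expected to stay within the scatter. For compound 4 the estimated value is 9500 nM, with an expected range from 4000 nM to 23000 nM.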

Compound 4, half-maximal inhibitory concentration: 8100 nM
Compound 4: middle estimate off by 1.2-fold (0.07 log units), on the high side; measured number inside the range.
By their numbers in this assay, from the lowest: compounds 4 and 3 (each within the scatter of the next); then compounds 1 and 2 (each within the scatter of the next).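

Working notes on the ester at this carbonyl carbon, read in this assay: the exchange of 4-fluorophenyl for 3,4-dichlorophenyl gives a 1.4-fold lower number from compound 3 to compound 4 (0.14 log units; within the scatter) and is the first measured swap of one substituted phenyl group for another, so two chlorine in place of one fluorine do not separate compound 3 from compound 4. The separation from the smaller and the more extended groups now holds for a second substituted phenyl group, with a 4.7-fold lower number from compound 1 to compound 4 (0.67 log units; beyond the scatter) against the methyl compound and a 5.0-fold lower number from compound 2 to compound 4 (0.70 log units; beyond the scatter) against the benzylamino compound, and among these four compounds none goes against this split, though both steps remain modest. No measured evidence is available to explain any of these steps.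

The compounds shown leave open whether a phenyl group carrying a different kind of substituent, such as methoxy, an amine or a carboxylic acid, would stay with compound 3 and compound 4 or move away from them. Among the compounds shown here, also open is how a longer chain between the carbonyl carbon and the phenyl ring would read, since benzylamino is the only linked group here.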